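This account rests on a few compounds, and the source may have more. Where it says the series, first, only, none or still open, it means among the compounds named here.

Working notes on a short series of sulfonamides measured in an assay on cells for inhibition of HSP60/HSP10 (Homo sapiens), with a stated time of 60 min; on this read-out lower numbers stand for stronger inhibition and higher numbers for weaker inhibition.

Compound 1 `O=S(=O)(Nc1ccc2oc(-c3ccccc3)nc2c1)c1cccs1` gives 90000 nM in this assay, the highest of the three numbers recorded. For the measured compounds named here, compound 2 `O=S(=O)(Nc1ccc(-c2nc3cc(NS(=O)(=O)c4ccccc4F)ccc3o2)cc1)c1ccccc1F` gives 57000 nM in this assay, a value that sits within the scatter of the one for compound 1, so no order between these two can be read. Compound 3 `O=S(=O)(Nc1ccc(-c2nc3ccccc3o2)cc1)c1ccc(Cl)c(C(F)(F)F)c1` gives 12000 nM in this assay, and this gap to compound 1 lies beyond the scatter; compound 3 thus stands clearly stronger than compound 1, while its relation to compound 2 is not resolved as a single-point step here. Going by the values given here, no pair of measured compounds differs in only one place, so no isolated structural step has a measured size.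

Compound 4 `O=S(=O)(Nc1ccc2oc(-c3ccccc3)nc2c1)c1cccc(Cl)c1` has not yet been measured. Relative to compound 1 the change is 3-chlorophenyl in place of thiophen-2-yl on a sulfonyl sulfur. Among the compounds with values here, with no measured single-point step to lean on, the expectation rests only on the spread seen across compounds 1, 2 and 3. A step toward stronger inhibition is expected, of a size at about the edge of the scatter rather than well beyond it, a 2.3-fold lower number from compound 1 to compound 4 (0.35 log units; beyond the scatter). Compound 4 is therefore estimated at 40000 nM in this assay, with a range from 15000 nM to 100000 nM.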

Compound 4, half-maximal inhibitory concentration: > 100000 nM
Compound 4 was reported as a limit; the forecaster's own chance of this, stated with the estimate: 10%; middle value at least 2.5-fold (0.39 log units) from the limit.
By their numbers in this assay, from the lowest: compound 3; then compounds 2 and 1 (each within the scatter of the next). At a limit, above all of these: compound 4.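

This gives the series its first measured step at a single place: on a sulfonyl sulfur whose other neighbour is the sulfonamide nitrogen, 3-chlorophenyl in place of thiophen-2-yl gives an at least 1.1-fold higher number from compound 1 to compound 4 (0.04 log units; that floor lies within the scatter) in this assay. The change therefore brings no stronger inhibition at this position, although the floor of the step alone does not establish a real loss and its full size cannot be read. The reading for compound 4 is a limit of the assay and not a number: the limit of > 100000 nM in this assay, at which 1 of the 4 values shown sits.

One step replaces the ring and adds the chlorine together, so it leaves open whether either change alone would shift the number, and how far the true value of compound 4 lies past the limit. Also open, as far as these compounds go, is how this sulfonyl position would respond to a group of another kind, such as a longer alkyl chain or a phenyl ring carrying a carboxylic acid.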